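Trifluoromethyl for Methoxy: Expected Cytotoxicity of Compound 4

This account rests on a few compounds, and the source may have more. Where it says the series, first, only, none or still open, it means among the compounds named here.

Three compounds share one core and differ only in where a methoxy sits on the outer ring: compound 1 `COc1ccccc1/C=C/C(=O)c1cc(NC(C)=O)ccc1O`, compound 2 `COc1cccc(/C=C/C(=O)c2cc(NC(C)=O)ccc2O)c1` and compound 3 `COc1ccc(/C=C/C(=O)c2cc(NC(C)=O)ccc2O)cc1`. In an ADME assay on MT4 cells (Homo sapiens) for cytotoxicity, read by MTT assay, with a stated time of 4 days (on this read-out lower numbers stand for higher toxicity in this test and higher numbers for lower toxicity in this test), compound 1 gives 37800 nM, compound 2 gives 40000 nM and compound 3 gives 38700 nM. Compound 2 holds the largest of these three numbers, yet both others lie within the usual scatter of it, so the three cannot be told apart.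

Compound 4 `CC(=O)Nc1ccc(O)c(C(=O)/C=C/c2cccc(C(F)(F)F)c2)c1` is not yet measured. It differs from compound 2 by trifluoromethyl in place of methoxy on an aromatic carbon. Because the measured values of compound 1 37800 nM and compound 3 38700 nM stay so close, no step beyond the scatter is expected in this assay, the expected step being a 1.1-fold lower number from compound 2 to compound 4 (0.02 log units; within the scatter). Compound 4 is therefore estimated at 38000 nM, between 18000 nM and 80000 nM.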

Compound 4, half-maximal cytotoxic concentration: 32100 nM
Compound 4: the middle estimate sits 1.2-fold (0.07 log units) above what was measured; the range from low to high includes it.
By their numbers in this assay, from the lowest: compounds 4, 1, 3 and 2 (each within the scatter of the next).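

In this assay, for the compounds shown here, trifluoromethyl in place of methoxy on this aromatic carbon brings a 1.2-fold lower number from compound 2 to compound 4 (0.10 log units; within the scatter) and so no step that can be told from the scatter. The earlier compounds shown here varied only where methoxy sits, whereas this result shows that the group itself can be exchanged at this place with the number staying within the scatter. Nothing measured here bears on why that is so. From the compounds shown here alone, an amine, a carboxylic acid or a longer chain at this place remains open. So does trifluoromethyl where compound 1 and compound 3 carry methoxy.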